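Fluoro for Methyl Repeated on a Weaker Core

The source may report more compounds than this note shows. Statements on the series, on what has been measured and on what is new or still open speak of the compounds shown alone.

Compound 1 `Cc1ccc2oc(-c3ccc(NC(=O)CN4CCN(CCN(C)C)CC4)cc3)nc2c1` is the reference: in a functional assay on HepG2 cells (Homo sapiens) for cytotoxicity, read by MTT assay, with a stated time of 24 h (a lower number here means a stronger inhibitor, a higher number a weaker inhibitor), compound 1 gives 1270 nM. Compound 2 `CN(C)CCN1CCN(CC(=O)Nc2ccc(-c3nc4cc(F)ccc4o3)cc2)CC1` differs by one change, (fluoro in place of methyl on an aromatic carbon), and in this assay compound 2 gives 18800 nM, a step of a 15-fold higher number from compound 1 to compound 2 (1.17 log units; beyond the scatter). Compound 3 `Cc1ccc2oc(-c3ccc(NC(=O)CCl)cc3)nc2c1` has a different core from compound 1; the difference between the two cores is not broken down here. In this assay compound 3 gives 21500 nM, which lies within the scatter of compound 2. Compound 4 `O=C(CCl)Nc1ccc(-c2nc3cc(F)ccc3o2)cc1` applies the same change to compound 3: fluoro in place of methyl on an aromatic carbon. A smaller step than a 15-fold higher number from compound 1 to compound 2 (1.17 log units; beyond the scatter) is expected this time. The expected step is a 2.3-fold higher number from compound 3 to compound 4 (0.37 log units; beyond the scatter), because compound 3 already stands at 21500 nM, a high number for this kind of assay. Compound 4 is therefore estimated at 50000 nM, between 15000 nM and 200000 nM.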

Compound 4, half-maximal inhibitory concentration: 8120 nM
Compound 4: the middle estimate sits 6.2-fold (0.79 log units) above what was measured; measured number below the stated range.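

In this assay, fluoro in place of methyl on an aromatic carbon gives a 2.6-fold lower number from compound 3 to compound 4 (0.42 log units; beyond the scatter), the opposite direction to the step seen on the core of compound 1. The change therefore did not carry over from one core to the other, in either direction or size: the same change on two cores in this assay, a 15-fold higher number (1.17 log units; beyond the scatter) from compound 1 to compound 2 and a 2.6-fold lower number (0.42 log units; beyond the scatter) from compound 3 to compound 4, 39-fold (1.59 log units) apart, beyond the scatter of two such steps. This shows that the outcome of the change differs between these two pairs, but it does not show which part of the cores is responsible or how the change would behave on a third core.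

The compounds shown leave open how a methoxy or trifluoromethyl group on that same aromatic carbon would compare on each core. They also leave open whether an amide side chain ending in a morpholine would follow either pair.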